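Compound 2 and a Step from Methyl to Hydroxymethyl

A few compounds are considered here, and "the series" means these few. Any claim that something is new, unique, unknown or untested is made for them only; others in the source may bear on it.

Of the compounds shown here, three have been measured in a functional assay on MIA PaCa-2 cells (Homo sapiens) for inhibition, read by MTT assay, with a stated time of 72 h, tested at 30 uM; a higher number here means more inhibition of growth at the concentration tested, a lower number less inhibition of growth. There, compound 3 `C#CCOc1ccc(CC=C)cc1O` gives 27.4%, compound 1 `C=CCc1ccc(OCc2cn(-c3cccc([N+](=O)[O-])c3)nn2)c(O)c1` gives 42.9%, and compound 2 `C=CCc1cc(O)c(O)c(CN2CCC(C)CC2)c1` gives 91.5%. Compound 2 thus stands highest of the three, and its gaps to both others lie beyond the scatter. No two of these compounds differ in one place only, so the numbers offer no measured single change to lean on.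

The next compound, compound 4 `C=CCc1cc(O)c(O)c(CN2CCC(CO)CC2)c1`, differs from compound 2 in one place: hydroxy in place of hydrogen on a saturated chain carbon bound to a saturated ring carbon. This is hydroxy in place of hydrogen on a saturated chain carbon bound to a saturated ring carbon, which reads as methyl to hydroxymethyl. For the measured compounds named here, nothing measured so far shows what this change does in this assay, so the expectation rests on the standing of compound 2 alone. With compound 2 at 91.5%, little room remains upward, and a fall is more likely than a rise. The expected change is a number 11.5 percentage points lower from compound 2 to compound 4 (beyond the scatter), a modest fall close to the edge of the scatter. For compound 4 the estimated value is 80%, with an expected range from 55% to 97%.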

Compound 4, percent growth inhibition at one concentration: 34.1%
Compound 4: middle estimate off by 45.9 percentage points, on the high side, and the stated range ends above it.
By their numbers in this assay, from the lowest: compounds 3, 4 and 1 (each within the scatter of the next, the first and the last beyond it); then compound 2.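

For the compounds shown here, the step from methyl to hydroxymethyl gives the first measured single change: in this assay it is a number 57.4 percentage points lower from compound 2 to compound 4 (beyond the scatter). It shows that the high number of compound 2 does not rest on the shared core alone, since one hydroxy group, entering on a saturated chain carbon bound to a saturated ring carbon, is enough to change the result greatly, so this position is far from indifferent in this assay. Nothing shown here explains how the change acts, and the result stands as an observation from this one pair.

Going by these compounds, it remains open whether the fall belongs to the hydroxy group itself or would follow from other groups at this place, and whether it would recur on another core. A methoxymethyl group, a carboxylic acid, an aminomethyl group or a longer chain such as ethyl at the same place could separate these readings, as could a ring carrying no methyl group at all.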